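From 2-chlorobenzyl to 4-(tert-butyl)benzyl in compound 4

A few compounds are considered here, and "the series" means these few. Any claim that something is new, unique, unknown or untested is made for them only; others in the source may bear on it.

Of the compounds shown here, three built on a shared core have been measured so far. In a functional assay on A549 cells (Homo sapiens) for cytotoxicity, read by MTT assay, with a stated time of 72 h (a higher number here means a weaker inhibitor, a lower number a stronger inhibitor), compound 2 `CN(C)Cc1ccc2nc(NC(=O)N/N=C/c3cn(Cc4ccccc4Cl)c4ccccc34)sc2c1` gives 1080 nM. Compound 1 `CCN(CC)Cc1ccc2nc(NC(=O)N/N=C/c3cn(Cc4ccc(C(C)(C)C)cc4)c4ccccc34)sc2c1` gives 1710 nM, which lies within the usual scatter of compound 2, so these two numbers cannot be told apart. Compound 3 `CC1CCN(Cc2ccc3nc(NC(=O)N/N=C/c4cn(Cc5ccc(Cl)cc5Cl)c5ccccc45)sc3c2)CC1` gives 3640 nM, a higher number than compound 2 by more than the scatter, and so a weaker inhibitor.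

Compound 4 `CN(C)Cc1ccc2nc(NC(=O)N/N=C/c3cn(Cc4ccc(C(C)(C)C)cc4)c4ccccc34)sc2c1` has not been measured yet. It differs from compound 2 in one place, on a saturated chain carbon bound to an aromatic nitrogen: 4-(tert-butyl)phenyl in place of 2-chlorophenyl on a saturated chain carbon bound to an aromatic nitrogen. Cut one bond further out, the same difference reads 2-chlorobenzyl to 4-(tert-butyl)benzyl.

Among the compounds with values here, no pair of measured compounds shows this change on its own, so the evidence is indirect. Compound 1 also carries the 4-(tert-butyl)benzyl group and gives 1710 nM, so only a small rise in the number is expected in this assay. The estimated step of a 1.4-fold higher number from compound 2 to compound 4 (0.14 log units; within the scatter) is expected to stay within the scatter. For compound 4 the estimated value is 1500 nM, with an expected range of 700 nM to 3200 nM.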

Compound 4, half-maximal inhibitory concentration: 1850 nM
Beside the measured number, compound 4's estimate is 1.2-fold (0.09 log units) below it, and the stated range covers the measured number.
By their numbers in this assay, from the lowest: compounds 2, 1, 4 and 3 (each within the scatter of the next, the first and the last beyond it).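

In this assay, the swap of 2-chlorobenzyl for 4-(tert-butyl)benzyl on a saturated chain carbon bound to an aromatic nitrogen can now be read on its own, and it gives a 1.7-fold higher number from compound 2 to compound 4 (0.23 log units; within the scatter). This position therefore accepts the larger group, the entering 4-(tert-butyl)phenyl against the leaving 2-chlorophenyl, without a difference that can be told apart from the scatter. A second single change also becomes readable, dimethylamino in place of diethylamino on a saturated chain carbon bound to an aromatic carbon, which gives a 1.1-fold higher number from compound 1 to compound 4 (0.03 log units; within the scatter) and likewise cannot be told apart, and nothing on hand offers a reason for either result.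

This swap alters both the substituent and its place on the ring at once, and the compounds shown cannot separate those two parts. Also open, on these data alone, is how an unsubstituted benzyl group, or a benzyl group carrying a carboxylic acid, would read in this assay, and whether any group here can produce a step beyond the scatter.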